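The source may hold more compounds than are shown below. What is called first, only, known or untested is meant among the compounds shown, and "the series" means these compounds.

Measured so far:
Compound 1, `Cc1ccc(C(=O)Nc2cc(-c3ccccc3)nn2-c2ccccc2)cc1`: in an assay on isolated protein with metabotropic glutamate receptor 5 (Rattus norvegicus) as the target (on this read-out higher numbers stand for an effect only at larger amounts of compound and lower numbers for an effect already at smaller amounts), compound 1 gives 40 nM.
Compound 2, `O=C(Nc1cc(-c2ccccc2)nn1-c1ccccc1)c1ccccc1O`: in this assay compound 2 reaches only > 10000 nM, which is a limit of the assay and not a number.

For the measured compounds named here, compound 1 thus holds the only number in this assay; the other value shown for the series is a limit (the limit of > 10000 nM in this assay, at which 1 of the 2 values shown sits). Going by the values given here, the one measured step, an at least 250-fold higher number from compound 1 to compound 2 (2.39 log units; beyond the scatter), concerns 2-hydroxyphenyl in place of 4-methylphenyl on the carbonyl carbon and is large. Compound 3, `O=C(Nc1cc(-c2ccccc2)nn1-c1ccccc1)c1ccc(C(F)(F)F)cc1`, is not yet measured. It differs from compound 1 thus: trifluoromethyl in place of methyl on an aromatic carbon. Among the compounds with values here, no measured step covers this exchange; the step from compound 1 to compound 2 alters the same part of the molecule but through a different group, so it gives no direction for the present change. Within the data shown here, with no bearing step, the expectation for this assay is a step within the usual scatter, no change at the digits printed from compound 1 to compound 3 (within the scatter). Compound 3 is accordingly estimated at 40 nM in this assay, with a range from 10 nM to 200 nM.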

Compound 3, half-maximal effective concentration: 20 nM
Compound 3: the middle estimate sits 2.0-fold (0.30 log units) above what was measured; the measured number falls inside the stated range.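

Working notes on the series. In this assay, the aromatic carbon para to a large group accepts trifluoromethyl in place of methyl, with a 2.0-fold lower number from compound 1 to compound 3 (0.30 log units; within the scatter), so at this place the read-out does not separate the two groups and the added fluorine atoms carry no visible cost. Exchange of 2-hydroxyphenyl for 4-(trifluoromethyl)phenyl on the carbonyl carbon gives an at least 500-fold lower number from compound 2 to compound 3 (2.69 log units; beyond the scatter), which shows that the large loss seen with compound 2 is not a general feature of changing this aryl group, since compound 3 keeps a value in the range of compound 1. The value of compound 2 is a limit and not a number, so the true size of that step stays unknown: the limit of > 10000 nM in this assay, at which 1 of the 3 values shown sits.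

Compound 2 differs from compound 1 and compound 3 in both the group and its place on the ring, so the shown compounds cannot tell whether the hydroxyl itself or its location accounts for the loss. Also open, going by these compounds, is how this place responds to a hydroxyl in the position of the methyl, to an amine or a carboxylic acid, or to a longer chain such as ethyl.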